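This account rests on a few compounds, and the source may have more. Where it says the series, first, only, none or still open, it means among the compounds named here.

Compound 1 `COc1cc(C2=NN(C(C)=O)C(c3ccc(F)cc3)O2)cc(OC)c1OC` and compound 2 `COc1cc(C2=NN(C(C)=O)C(c3cc(OC)c(OC)c(OC)c3)O2)cc(OC)c1OC` share one core and were both tested in a functional assay on BGC-823 cells (Homo sapiens) for antiproliferative activity, read by MTT assay, tested at 1 uM; a higher number here means a stronger effect of the compound at the concentration tested, a lower number a weaker effect. In this assay compound 1 gives -0.4%, and compound 2 gives -1.8%; the two numbers lie within the usual scatter of each other, so compound 1 cannot be set apart from compound 2 at this concentration. Compound 3 `COc1cc(C2=NN(C(C)=O)C(c3ccc(C(F)(F)F)cc3)O2)cc(OC)c1OC` has not been measured yet. Its structure differs from compound 1 by trifluoromethyl in place of fluoro on an aromatic carbon. Among the measured compounds shown here, no measured pair shows what such a change does here, so the step of a number 1.4 percentage points higher from compound 1 to compound 3 (within the scatter) is expected to be none beyond the scatter. Compound 3 is therefore estimated at 1%, between -10% and 14%.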

Compound 3, a percentage reported as inhibition, at one concentration (the size of the read-out at that concentration, not a potency): 4.2%
Compound 3: middle estimate off by 3.2 percentage points, on the low side; the measured number falls inside the stated range.
By their numbers in this assay, from the lowest: compounds 2, 1 and 3 (each within the scatter of the next).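

Among the compounds shown here, replacing fluoro with trifluoromethyl on this aromatic carbon, para to a large group, gives the first comparison of two compounds that differ in one place: in this assay, the swap gives a number 4.6 percentage points higher from compound 1 to compound 3 (within the scatter). At this concentration, therefore, these two groups cannot be told apart at this position. Nothing available explains this result.

Going by these compounds, whether an amine, a carboxylic acid or a longer chain at this position would shift the number beyond the scatter remains open. So does whether these compounds would show any clear effect at a higher concentration.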